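Urea series: amide nitrogen substituent on the cinnamamide arm

The compounds below may be only part of what the source reports. "The series", "measured", "known", "first", "only" and "open" are said of these compounds alone.

Measured compounds in a functional assay on HT-29 cells (Homo sapiens) for inhibition, read by MTT assay, with a stated time of 120 h; on this read-out lower numbers stand for stronger inhibition and higher numbers for weaker inhibition:
compound 1 `CNC(=O)/C=C(\C)c1ccc(NC(=O)Nc2ccc(Cl)c(C(F)(F)F)c2)cc1`, > 50000 nM; this is a limit of the assay, not a number.
compound 2 `O=C(CCc1ccc(NC(=O)Nc2ccc(Cl)c(C(F)(F)F)c2)cc1)NC1CCC1`, 21300 nM
compound 3 `O=C(/C=C/c1ccc(NC(=O)Nc2ccc(Cl)c(C(F)(F)F)c2)cc1)NC1CCC1`, 4430 nM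

Compound 3 gives the lowest of the two numbers; its nearest neighbour is compound 2, with a 4.8-fold lower number from compound 2 to compound 3 (0.68 log units; beyond the scatter). Compound 4 `CC1CN(C(=O)/C=C/c2ccc(NC(=O)Nc3ccc(Cl)c(C(F)(F)F)c3)cc2)CC(C)O1` differs from compound 3 by 2,6-dimethylmorpholin-4-yl in place of cyclobutylamino on a carbonyl carbon. Going by the values given here, none of the measured steps touches the amide nitrogen: an at least 2.3-fold lower number from compound 1 to compound 2 (0.37 log units; beyond the scatter) and an at least 11-fold lower number from compound 1 to compound 3 (1.05 log units; beyond the scatter) change the chain, and the step from compound 2 to compound 3 changes its saturation. The move to compound 4 is therefore uncharted here. The expected step of a 1.5-fold higher number from compound 3 to compound 4 (0.17 log units; within the scatter) is small, a somewhat higher number at most. Compound 4 is estimated at 6500 nM, within 1500 nM to 28000 nM.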

Compound 4, half-maximal inhibitory concentration: 9100 nM
Compound 4: the middle estimate sits 1.4-fold (0.15 log units) below what was measured, within the range that was stated.
By their numbers in this assay, from the lowest: compound 3; then compound 4; then compound 2. At a limit, above all of these: compound 1.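

In this assay, going by these compounds alone, the first change at the amide nitrogen gives a 2.1-fold higher number from compound 3 to compound 4 (0.31 log units; beyond the scatter), so the cyclobutylamino group can be replaced by the larger 2,6-dimethylmorpholin-4-yl at a modest cost. Compound 4 has no amide hydrogen yet still gives a measured value, so that hydrogen is not needed for a reading in this assay. Nothing shown here accounts for the step.

Unsubstituted morpholine and piperidine on the same carbonyl remain open, and these would separate the contributions of the ring oxygen and the two methyl groups. A simple secondary amide bearing a cyclohexyl group would likewise test ring size while keeping the amide hydrogen.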